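A few compounds are considered here, and "the series" means these few. Any claim that something is new, unique, unknown or untested is made for them only; others in the source may bear on it.

Four close relatives share one core and differ only in a halogen on the outer ring and in where that halogen sits. Compound 1 `CN1CCN(c2ccc(S(=O)(=O)Oc3cccc(F)c3)cc2)C1=O` and compound 2 `CN1CCN(c2ccc(S(=O)(=O)Oc3cccc(Cl)c3)cc2)C1=O` form one pair; compound 3 `CN1CCN(c2ccc(S(=O)(=O)Oc3ccc(F)cc3)cc2)C1=O` and compound 4 `CN1CCN(c2ccc(S(=O)(=O)Oc3ccc(Cl)cc3)cc2)C1=O` form the other. In a functional assay on HT-29 cells (Homo sapiens) for antiproliferative activity, read by sulforhodamine B assay, with a stated time of 48 h (on this read-out lower numbers stand for stronger inhibition and higher numbers for weaker inhibition), compound 1 gives only a limit, > 100000 nM. Compound 2 gives 2100 nM. Compound 3 also gives only a limit, > 100000 nM. The step of an at least 47-fold lower number from compound 1 to compound 2 (1.67 log units; beyond the scatter) follows (chloro in place of fluoro on an aromatic carbon). The two cores differ by 4-fluorophenyl in place of 3-fluorophenyl on an oxygen; a step that the two limits leave unreadable from compound 1 to compound 3, whereas an at least 47-fold higher number from compound 2 to compound 3 (1.67 log units; beyond the scatter). Compound 4 makes the same kind of change, (chloro in place of fluoro on an aromatic carbon), though para to a large group rather than meta to a large group. Two of the three values rest at the limit of > 100000 nM in this assay, at which 2 of the 3 values shown sit. The expected step of an at least 16-fold lower number from compound 3 to compound 4 (1.22 log units; beyond the scatter) rests on the earlier one because an at least 47-fold lower number from compound 1 to compound 2 (1.67 log units; beyond the scatter) was large. Compound 4 is thus estimated at 6000 nM, most likely between 1000 nM and 100000 nM.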

Compound 4, half-maximal inhibitory concentration: 12000 nM
Estimate against measurement, compound 4: 2.0-fold (0.30 log units) below; low and high end bracket the measured number.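

Chloro in place of fluoro gives a lower number in this assay on both cores, and the new step, an at least 8.3-fold lower number from compound 3 to compound 4 (0.92 log units; beyond the scatter), points the same way as the earlier one. The size of the change is not shown to carry over, and the two steps cannot be compared: the same change on two cores in this assay, an at least 47-fold lower number (1.67 log units; beyond the scatter) from compound 1 to compound 2 and an at least 8.3-fold lower number (0.92 log units; beyond the scatter) from compound 3 to compound 4; the limit leaves it open whether they differ. With chloro on both compounds, moving the group also matters, as seen in a 5.7-fold higher number from compound 2 to compound 4 (0.76 log units; beyond the scatter), whereas an at least 8.3-fold lower number from compound 1 to compound 4 (0.92 log units; beyond the scatter) changes the halogen and its position together.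

Going by these compounds, how weak the two fluoro compounds really are remains open, as their values are only limits: the limit of > 100000 nM in this assay, at which 2 of the 4 values shown sit. On these data alone, it is also open whether bromo or methyl in either position would behave like chloro.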